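Hydroxy on the pendant phenyl of the thiourea series

A few compounds are considered here, and "the series" means these few. Any claim that something is new, unique, unknown or untested is made for them only; others in the source may bear on it.

Measured so far:
compound 1, `COc1cc(/C=C/C(=O)C2=C(/C=C/c3ccc(O)c(OC)c3)NC(=O)NC2c2ccc(O)cc2)ccc1O`: 33.3%
compound 2, `COc1cc(/C=C/C(=O)C2=C(/C=C/c3ccc(O)c(OC)c3)NC(=S)NC2c2ccccc2)ccc1O`: 16.6%

In a functional assay, with a stated time of 20 min, tested at 2 uM (a higher number here means a stronger effect of the compound at the concentration tested, a lower number a weaker effect), compound 2 gives 16.6%, the lower of the two numbers; compound 1 gives 33.3%, a gap beyond the scatter. Among the compounds with values here, no single-point step between these two is available, so the pair only shows that the numbers differ; compound 1 differs from compound 2 in more than one place.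

Compound 3, `COc1cc(/C=C/C(=O)C2=C(/C=C/c3ccc(O)c(OC)c3)NC(=S)NC2c2ccccc2O)ccc1O`, is yet to be measured. The change from compound 2 to compound 3 is hydroxy in place of hydrogen on an aromatic carbon.

With no measured step of this kind in hand, the expected change from compound 2 to compound 3 is small, at most a modest rise, and may well stay within the scatter: a number 5.4 percentage points higher from compound 2 to compound 3 (within the scatter). Within the data shown here, for compound 3 the estimated value is 22%, with a range from 8% to 40%, set wide because the only anchor is compound 2 at 16.6%.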

Compound 3, a percentage reported as activity, at one concentration (the size of the read-out at that concentration, not a potency): 34%
Compound 3: the middle estimate sits 12 percentage points below what was measured, within the range that was stated.
By their numbers in this assay, from the lowest: compound 2; then compounds 1 and 3 (each within the scatter of the next).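

In this assay, the series now has its first single-place step, a number 17.4 percentage points higher from compound 2 to compound 3 (beyond the scatter), for phenyl to 2-hydroxyphenyl, with the hydroxy ortho to a large group. This shows that the read-out responds to a change at this one place on the pendant ring, which the pair of compound 1 and compound 2 could not show, as those two differ in more than one place. Nothing at hand bears on the reason for this step.

From the compounds shown here alone, whether the step is specific to hydroxy remains open, and a methoxy, an amine or a fluorine at the same place would test this. Also open is whether hydroxy on another carbon of this ring gives a similar step, and a single concentration gives no potency for any of these compounds.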